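Hydroxypiperidine substituent swap on the cinnamamide core

This account rests on a few compounds, and the source may have more. Where it says the series, first, only, none or still open, it means among the compounds named here.

Compound 1 `COCCC1(O)CCN(c2nc(C)c3cc(NC(=O)/C=C/c4ccc(Cl)cc4)ccc3n2)CC1` is one of two compounds with a number in a functional assay on CHO-K1 cells for antagonist activity at melanin-concentrating hormone receptor 1 (Homo sapiens), read by inositol phosphate accumulation, with stated times of 10 min and 45 min; on this read-out higher numbers stand for weaker inhibition and lower numbers for stronger inhibition. In this assay, for the measured compounds named here, compound 1 gives 220 nM, the higher of the two; compound 2 `Cc1nc(NCCCNS(C)(=O)=O)nc2ccc(NC(=O)/C=C/c3ccc(OC(F)(F)F)cc3)cc12` gives 32 nM, a lower number beyond the scatter, though the two structures differ in several places and no single step links them. Compound 3 `Cc1nc(N2CCC(O)(C3CCC3)CC2)nc2ccc(NC(=O)/C=C/c3ccc(Cl)cc3)cc12` is not yet measured; it differs from compound 1 by cyclobutyl in place of 2-methoxyethyl on a saturated ring carbon. Going by the values given here, no measured step shows what this change does, so the step from compound 1 to compound 3 is expected to be a 1.1-fold lower number from compound 1 to compound 3 (0.04 log units; within the scatter), within the scatter. Compound 3 is estimated at 200 nM, with a range of 70 nM to 600 nM.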

Compound 3, half-maximal inhibitory concentration: 54 nM
Compound 3: middle estimate off by 3.7-fold (0.57 log units), on the high side; measured number outside the range, below it.
By their numbers in this assay, from the lowest: compounds 2 and 3 (each within the scatter of the next); then compound 1.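

In this assay, cyclobutyl in place of 2-methoxyethyl on this saturated ring carbon gives a 4.1-fold lower number from compound 1 to compound 3 (0.61 log units; beyond the scatter). This single-place step shows that the read-out responds to the group held here, even though the two groups have the same heavy-atom count. No measurement shown accounts for the step. The change both adds a ring and removes the chain oxygen, so the compounds shown do not separate these two differences. A plain butyl chain or a cyclopentyl ring at this carbon would test which difference goes with the lower number.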